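The source may report more compounds than this note shows. Statements on the series, on what has been measured and on what is new or still open speak of the compounds shown alone.

Compound 1 `CCN(CC)c1cc2[nH]c(C3CCCCC3)nc2cc1NC(=O)c1ccc(OC(F)F)cc1` in an ADME assay on Vero cells (Chlorocebus sabaeus) for cytotoxicity, read by resazurin assay, with a stated time of 3 days (a lower number here means a stronger inhibitor, a higher number a weaker inhibitor), gives > 100 ug/mL, which is a limit of the assay.
Compound 2 `CN(C)c1cc2[nH]c(C3CCCCC3)nc2cc1NC(=O)c1ccc(OC(F)F)cc1` gives > 100 ug/mL, also a limit.
Compound 3 `CCc1ccc(C(=O)Nc2cc3nc(C4CCCCC4)[nH]c3cc2N(C)C)cc1` gives > 100 ug/mL, again a limit.

Compound 1 thus stands only at a limit, with no number to place it, and the same holds for compound 2 and compound 3, so that the limit of > 100 ug/mL in this assay, at which 3 of the 3 values shown sit, is all the evidence there is. The step to compound 4 `CCN(CC)c1cc2[nH]c(C3CCCCC3)nc2cc1NC(=O)c1cccc(Br)c1` changes (3-bromophenyl in place of 4-(difluoromethoxy)phenyl on a carbonyl carbon). The measured steps a step that the two limits leave unreadable from compound 1 to compound 2 and a step that the two limits leave unreadable from compound 2 to compound 3 alter the amino group and the ring on the carbonyl carbon, but both run between limits and give no readable size. No step beyond the scatter is expected for a number no higher from compound 1 to compound 4 (the limit leaves the size open). Compound 4 is therefore estimated at 100 ug/mL, between 40 ug/mL and 250 ug/mL, most probably reported once more as a limit.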

Compound 4, half-maximal inhibitory concentration: > 100 ug/mL
Compound 4 ended at the assay's limit; the forecaster's own chance of this, stated with the estimate: 75%; the middle value lies on the limit itself.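

Compound 1 and compound 4 both stand only at a limit in this assay, so the change between them cannot be read as a step. The compounds shown leave open what number any of them would give, as all rest on a limit: the limit of > 100 ug/mL in this assay, at which 4 of the 4 values shown sit.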